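The compounds below may be only part of what the source reports. "The series", "measured", "known", "first", "only" and "open" are said of these compounds alone.

Measured exposure in the series:

Compound 1 `Cc1nnc(N2CCC(C(=O)N3N=CC[C@H]3c3cc(F)cc(F)c3)CC2)o1` gives 1300 ng.h/mL in an ADME assay on the whole organism (Rattus norvegicus) for pharmacokinetics, at a dose of 1 mg/kg by the intravenous route; a higher number here means more compound in the circulation at the dose given, a lower number less compound in the circulation.
Compound 2 `O=C(c1cn[nH]c1)N1CCC(C(=O)N2N=CCC2c2ccccc2)CC1` gives 360 ng.h/mL.
Compound 3 `O=C(c1cnco1)N1CCC(C(=O)N2N=CC[C@H]2c2ccccc2)CC1` gives 400 ng.h/mL.

Compound 1 stands highest of the three numbers. Compound 3 is nearest to it and compound 2 furthest, and both of those lie below compound 1 by more than the usual scatter of this measurement. Compound 2 and compound 3 themselves sit close together, within the scatter of each other, so no order is read between them. For the measured compounds named here, no pair among the measured compounds differs in a single place, so no measured step is available to lean on.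

Compound 4 `N#Cc1cc(N2CCC(C(=O)N3N=CC[C@H]3c3cc(F)cc(F)c3)CC2)ncn1` is the next member and differs from compound 1 in one place: a group of 8 heavy atoms (5 carbon, 3 nitrogen; one six-membered aromatic ring with 2 hetero atoms) in place of a group of 6 heavy atoms (3 carbon, 2 nitrogen, 1 oxygen; one five-membered aromatic ring with 3 hetero atoms), on an amine nitrogen in a ring

The remainder of the molecule, including the difluorophenyl ring and the shared core of compound 1, is kept. With nothing measured for a change of this kind, the expectation is a modest step from compound 1, most likely downward, and not far beyond the scatter. The expected step of a 1.4-fold lower number from compound 1 to compound 4 (0.16 log units; within the scatter) is therefore set small and negative. Compound 4 is estimated at 900 ng.h/mL in this assay, with a range from 300 ng.h/mL to 2700 ng.h/mL.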

Compound 4, area under the concentration-time curve: 410 ng.h/mL
The estimate for compound 4 lay 2.2-fold (0.34 log units) above the measured number, within the range that was stated.
By their numbers in this assay, from the lowest: compounds 2, 3 and 4 (each within the scatter of the next); then compound 1.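

In this assay, for the compounds shown here, this pair gives the first measured reading of the group on an amine nitrogen in a ring with the rest of compound 1 held fixed: placing the nitrile-bearing six-membered aromatic ring with 2 hetero atoms where 5-methyl-1,3,4-oxadiazol-2-yl stood gives a 3.2-fold lower number from compound 1 to compound 4 (0.50 log units; beyond the scatter). The position is therefore not indifferent to the group it carries, at least for these two groups. The two groups match in their counts of hydrogen-bond donors and acceptors and in having no net charge, so the step comes without any difference in those counts, and nothing measured here explains it.

As far as these compounds go, whether the step follows the ring size, the nitrile or the loss of the methyl stays open, as this single pair changes them all together. Also open, from the compounds shown here alone, are how a carboxylic acid, an open-chain amine or a simple methyl group on the same amine nitrogen would stand in this assay, and whether the step would hold with any core other than that of compound 1.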